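Fluorinated Carbonyl Substituents on a Shared Piperidine Carbamate Core

The source may hold more compounds than are shown below. What is called first, only, known or untested is meant among the compounds shown, and "the series" means these compounds.

Measured compounds:
compound 1 `Cc1nc(S(C)(=O)=O)ccc1Oc1ncnc(OC2CCN(C(=O)O[C@H](C)CF)CC2)c1F`, 196 nM
compound 2 `Cc1nc(S(C)(=O)=O)ccc1Oc1ncnc(OC2CCN(C(=O)OC3COC3)CC2)c1F`, 326 nM
compound 3 `Cc1nc(S(C)(=O)=O)ccc1Oc1ncnc(OC2CCN(C(=O)C(C)(F)F)CC2)c1F`, 37 nM

In a functional assay on isolated protein for inhibition of Glucose-dependent insulinotropic receptor (Homo sapiens), read by HTRF and cAMP accumulation (on this read-out higher numbers stand for an effect only at larger amounts of compound and lower numbers for an effect already at smaller amounts), compound 3 gives the lowest number of the three, below compound 1 by a 5.3-fold lower number from compound 1 to compound 3 (0.72 log units; beyond the scatter) and below compound 2 by an 8.8-fold lower number from compound 2 to compound 3 (0.95 log units; beyond the scatter), both beyond the scatter. Compound 1 and compound 2 lie within the scatter of each other, as a 1.7-fold higher number from compound 1 to compound 2 (0.22 log units; within the scatter) shows.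

Compound 4 `Cc1nc(S(C)(=O)=O)ccc1Oc1ncnc(OC2CCN(C(=O)C3(F)CCC3)CC2)c1F` differs from compound 3 in one place: a group of 5 heavy atoms (4 carbon, 1 fluorine; one four-membered non-aromatic ring of carbon only) in place of a group of 4 heavy atoms (2 carbon, 2 fluorine; no ring), on a carbonyl carbon. Both measured steps that touch this carbonyl carbon point the same way, from an oxygen-linked group towards a directly attached fluorinated carbon group, and both were modest. For the measured compounds named here, no measured step compares two such directly attached groups with each other, so the present change is weakly anchored. The fluorine count falls and a ring enters, and the piece expects a small loss, within or just beyond the scatter, as a 1.6-fold higher number from compound 3 to compound 4 (0.21 log units; within the scatter) in this assay. Compound 4 is estimated at 60 nM, with a range from 18 nM to 200 nM.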

Compound 4, half-maximal effective concentration: 24.7 nM
For compound 4 the middle estimate is 2.4-fold (0.39 log units) above the measured one; low and high end bracket the measured number.
By their numbers in this assay, from the lowest: compounds 4 and 3 (each within the scatter of the next); then compounds 1 and 2 (each within the scatter of the next).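

In this assay, for the compounds shown here, the first comparison of two directly attached fluorinated carbon groups on this carbonyl carbon gives a 1.5-fold lower number from compound 3 to compound 4 (0.18 log units; within the scatter) and thus does not separate the ring-bearing group from 1,1-difluoroethyl. The lower numbers seen against oxygen-linked groups extend to the new group, since a 13-fold lower number from compound 2 to compound 4 (1.12 log units; beyond the scatter) and a 7.9-fold lower number from compound 1 to compound 4 (0.90 log units; beyond the scatter) both point the same way. No measurement here explains these differences. The compounds shown leave open whether fluorine matters on this carbon, as a plain cyclobutyl group would test. They also leave open how an amine or a longer chain on the carbonyl carbon would read.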